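The source may report more compounds than this note shows. Statements on the series, on what has been measured and on what is new or still open speak of the compounds shown alone.

Working notes on a short series sharing one core. Compound 1 `CCNC(=O)[C@H]1OC(n2cnc3c(NC)ncnc32)[C@H](O)[C@@H]1O` gives 120 nM in an assay with adenosine receptor A1 (Rattus norvegicus) as the target; on this read-out higher numbers stand for weaker inhibition and lower numbers for stronger inhibition. Compound 2 `CCNC(=O)[C@H]1OC(n2cnc3c(NC4CCCCC4)ncnc32)[C@H](O)[C@@H]1O` gives 1.7 nM in this assay, and compound 3 `CCNC(=O)[C@H]1OC(n2cnc3c(Nc4ccc(OC)cc4)ncnc32)[C@H](O)[C@@H]1O` gives 4.6 nM in this assay. Every measured step changes only the substituent on a nitrogen on an aromatic ring: a 71-fold lower number from compound 1 to compound 2 (1.85 log units; beyond the scatter) and a 26-fold lower number from compound 1 to compound 3 (1.42 log units; beyond the scatter) are both large, while a 2.7-fold higher number from compound 2 to compound 3 (0.43 log units; beyond the scatter) is modest. Compound 3 thus stands second highest of the three numbers, with compound 2 nearest below it and compound 1 furthest above it.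

Compound 4 `COc1ccc(Nc2ncnc3c2ncn3C2O[C@H](C(=O)O)[C@@H](O)[C@H]2O)cc1` has not been measured in this assay. It differs from compound 3 in one place: hydroxy in place of ethylamino on a carbonyl carbon, in other words ethylcarbamoyl becomes carboxy. Among the measured compounds shown here, no measured step touches the carbonyl carbon; each step so far alters the group on the ring nitrogen, which compound 4 keeps unchanged from compound 3. The series therefore offers no direct gauge for this change, and the expectation rests on the change itself. A higher number than that of compound 3 is expected for compound 4, the step of a 110-fold higher number from compound 3 to compound 4 (2.04 log units; beyond the scatter) being estimated as beyond the scatter. For compound 4 the estimated value in this assay is 500 nM within a range from 50 nM to 5000 nM.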

Compound 4, half-maximal inhibitory concentration: 1 nM
Estimate against measurement, compound 4: 500-fold (2.70 log units) above, outside the stated range (below it).
By their numbers in this assay, from the lowest: compounds 4 and 2 (each within the scatter of the next); then compound 3; then compound 1.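

In this assay, among the compounds shown here, the only step at the carbonyl carbon is a 4.6-fold lower number from compound 3 to compound 4 (0.66 log units; beyond the scatter), so with 4-methoxyphenyl on the ring nitrogen, ethylcarbamoyl is not needed here for a low number, and carboxy is accepted in its place. The earlier steps shown here all altered the group on the ring nitrogen and said nothing about this position; this one shows that the group on the carbonyl carbon also moves the number beyond the scatter, and that exchanging ethylamino for hydroxy moves it towards stronger inhibition. Nothing at hand bears on the reason for this step.

Going by these compounds, whether hydroxy in place of ethylamino gives a step of the same direction and size with methyl or cyclohexyl on the ring nitrogen remains open, as this change is read only with 4-methoxyphenyl. Also open, on these data alone, is how the number responds to other groups on the carbonyl carbon, such as a methyl ester, a primary amide, methylamino or a longer chain than ethylamino, and whether hydroxy or ethylamino is the exception among them.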